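A few compounds are considered here, and "the series" means these few. Any claim that something is new, unique, unknown or untested is made for them only; others in the source may bear on it.

Measured so far:
compound 1 `CN1CCC[C@H]1COc1cccnc1Br` — 451 nM
compound 2 `CSc1ncccc1OC[C@@H]1CCCN1C` — 559 nM

In an assay on membranes from brain for displacement of a labelled ligand from Neuronal acetylcholine receptor; alpha4/beta2 (Rattus norvegicus) (on this read-out lower numbers stand for stronger inhibition and higher numbers for weaker inhibition), compound 1 gives 451 nM and compound 2 gives 559 nM. Among the compounds with values here, compound 2 carries the highest of the two numbers, but its only neighbour is compound 1, and the step of a 1.2-fold higher number from compound 1 to compound 2 (0.09 log units; within the scatter) lies within the scatter, so the two are not distinguished by this assay.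

Compound 3 `CN1CCC[C@H]1COc1cccnc1[N+](=O)[O-]` is not yet measured. It differs from compound 2 by nitro in place of methylsulfanyl on an aromatic carbon.

Within the data shown here, the only measured step that bears on this position is a 1.2-fold higher number from compound 1 to compound 2 (0.09 log units; within the scatter): a swap of one group for another at the same aromatic carbon, with no change beyond the scatter. Among the measured compounds shown here, no step with a nitro group is available. On that basis, a step of a 1.4-fold lower number from compound 2 to compound 3 (0.15 log units; within the scatter) is expected, in either direction no larger than the scatter allows to resolve.

The estimate for compound 3 in this assay is 400 nM, with a range from 120 nM to 1400 nM.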

Compound 3, inhibition constant: 9000 nM
Beside the measured number, compound 3's estimate is 23-fold (1.35 log units) below it, and the stated range ends below it.
By their numbers in this assay, from the lowest: compounds 1 and 2 (each within the scatter of the next); then compound 3.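

In this assay the aromatic carbon next to the ring nitrogen turns out not to accept every group alike: nitro in place of methylsulfanyl gives a 16-fold higher number from compound 2 to compound 3 (1.21 log units; beyond the scatter) and nitro in place of bromo gives a 20-fold higher number from compound 1 to compound 3 (1.30 log units; beyond the scatter) on the same core. Compound 1 and compound 2 stayed within the scatter of each other, so that pair alone gave no sign that a swap at this carbon could move the number beyond the scatter. Nothing available gives a reason for this large step.

As far as these compounds go, whether the large step is specific to nitro or also appears with other groups at this carbon stays open; an amine, a nitrile or a methoxy group there would test this. Also open, from the compounds shown here alone, is whether a plain hydrogen at this carbon sits nearer to compound 1 or to compound 3.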